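This account rests on a few compounds, and the source may have more. Where it says the series, first, only, none or still open, it means among the compounds named here.

Measured compounds:
compound 1, `CCCCCC(=O)Nc1cccc(S(=O)(=O)Oc2ccccc2C(C)C)c1`: 11000 nM
compound 2, `CC(C)C(=O)Nc1cccc(S(=O)(=O)Oc2ccccc2C(C)C)c1`: 16000 nM
compound 3, `CC(C)c1ccccc1OS(=O)(=O)c1cccc(NC(=O)C(C)(C)C)c1`: 11000 nM

In a functional assay on HT-1080 cells (Homo sapiens) for antiproliferative activity, read by sulforhodamine B assay, with a stated time of 48 h (on this read-out higher numbers stand for weaker inhibition and lower numbers for stronger inhibition), compound 3 stands level with compound 1, and together the two give the lowest numbers of the three, while compound 2 is the furthest from compound 3, its gap still within the scatter. The three measured steps all change the group on the carbonyl carbon of the amide: a 1.5-fold higher number from compound 1 to compound 2 (0.16 log units; within the scatter), no change at the digits printed from compound 1 to compound 3 (within the scatter) and a 1.5-fold lower number from compound 2 to compound 3 (0.16 log units; within the scatter). None of them leaves the scatter, so the shared core appears to tolerate pentyl, isopropyl and tert-butyl at this position without a clear change in this assay.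

Compound 4, `CC(C)c1ccccc1OS(=O)(=O)c1cccc(NC(=O)CCCl)c1`, carries the change (2-chloroethyl in place of tert-butyl on a carbonyl carbon). For the measured compounds named here, every measured step at this carbonyl carbon was small, so the step of no change at the digits printed from compound 3 to compound 4 (within the scatter) is expected to stay within the scatter as well, with no clear direction; no measured compound carries chlorine, so the range is kept wide. Compound 4 is therefore estimated at 11000 nM, within 4500 nM to 27000 nM.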

Compound 4, half-maximal inhibitory concentration: 8200 nM
The estimate for compound 4 lay 1.3-fold (0.13 log units) above the measured number, and the stated range covers the measured number.
By their numbers in this assay, from the lowest: compounds 4, 1, 3 and 2 (each within the scatter of the next).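

In this assay the 2-chloroethyl group on this carbonyl carbon stays within the scatter of tert-butyl (a 1.3-fold lower number from compound 3 to compound 4 (0.13 log units; within the scatter)), of isopropyl (a 2.0-fold lower number from compound 2 to compound 4 (0.29 log units; within the scatter)) and of pentyl (a 1.3-fold lower number from compound 1 to compound 4 (0.13 log units; within the scatter)). The tolerance seen with pentyl, isopropyl and tert-butyl at this position therefore also holds, across these four compounds, for a group that carries chlorine, and no separation appears among the four. Nothing available bears on why this change leaves the number within the scatter.

The compounds shown leave open whether an amine, a carboxylic acid or a phenyl ring on this carbonyl carbon would take the number beyond the scatter. They also leave open whether a plain ethyl group there would read any differently from 2-chloroethyl.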